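Dichlorophenyl Urea Analogue Set Against Its Trifluoromethyl Precursors

The compounds below may be only part of what the source reports. "The series", "measured", "known", "first", "only" and "open" are said of these compounds alone.

Measured compounds:
compound 1 `COc1cc2cc(Oc3ccc(NC(=O)Nc4ccccc4)cc3)c(C)nc2cc1OC` gives 71.9%
compound 2 `COc1cc2cc(Oc3ccc(NC(=O)Nc4cccc(C(F)(F)F)c4)cc3)c(C)nc2cc1OC` gives 8.32%
compound 3 `COc1cc2cc(Oc3ccc(NC(=O)Nc4ccc(Cl)c(C(F)(F)F)c4)cc3)c(C)nc2cc1OC` gives 7.34%

Three ureas built on a shared core have been tested in a functional assay on OVCAR-8 cells (Homo sapiens) for inhibition, read by sulforhodamine B assay, with a stated time of 48 h, tested at 10 uM; on this read-out higher numbers stand for a weaker effect at the one concentration tested and lower numbers for a stronger effect. Compound 1 carries an unsubstituted phenyl on the urea and leaves most of the cell growth intact. The step of a number 63.6 percentage points lower from compound 1 to compound 2 (beyond the scatter), trifluoromethyl in place of hydrogen on an aromatic carbon, brings the read-out down sharply. The step of a number 64.6 percentage points lower from compound 1 to compound 3 (beyond the scatter), 4-chloro-3-(trifluoromethyl)phenyl in place of phenyl on an amide-type nitrogen, is of the same size. The further step a number 1 percentage points lower from compound 2 to compound 3 (within the scatter), chloro in place of hydrogen on an aromatic carbon, stays within the scatter.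

Compound 3 shows the lowest number of the three; compound 2 lies closest and cannot be separated from it, while compound 1 is far removed.

Compound 4 `COc1cc2cc(Oc3ccc(NC(=O)Nc4ccc(Cl)c(Cl)c4)cc3)c(C)nc2cc1OC` differs from compound 3 by chloro in place of trifluoromethyl on an aromatic carbon. Among the compounds with values here, no measured step covers this exchange directly. The large drop from compound 1 to compound 2 shows what the trifluoromethyl contributed, whereas the added chloro in compound 3 changed nothing beyond the scatter. Compound 4 keeps two chloro groups but loses the trifluoromethyl, so a step of modest size toward a higher number, possibly still within the scatter, is expected: a number 6.7 percentage points higher from compound 3 to compound 4 (within the scatter). Compound 4 is therefore estimated at 14%, in a range from 5% to 40%.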

Compound 4, a percentage reported as activity, at one concentration (the size of the read-out at that concentration, not a potency): 15%
Beside the measured number, compound 4's estimate is 1 percentage points below it, within the range that was stated.
By their numbers in this assay, from the lowest: compounds 3, 2 and 4 (each within the scatter of the next); then compound 1.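

In this assay, chloro in place of trifluoromethyl on this aromatic carbon, ortho to a chloro group, gives a number 7.7 percentage points higher from compound 3 to compound 4 (within the scatter), so among these compounds the trifluoromethyl is not needed here: one chlorine atom in place of the four heavy atoms of that group leaves a read-out that cannot be separated from that of compound 3. Within the data shown here, the comparison with the compound lacking the chloro group points the same way, with a number 6.7 percentage points higher from compound 2 to compound 4 (within the scatter) for 3,4-dichlorophenyl in place of 3-(trifluoromethyl)phenyl, while a number 56.9 percentage points lower from compound 1 to compound 4 (beyond the scatter) shows that the large gain over the unsubstituted phenyl, until now seen only with trifluoromethyl on the ring, also appears in a urea with no fluorine at all. Nothing available explains why these two groups cannot be told apart at this position.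

From the compounds shown here alone, whether a methoxy group, a nitrile, a dimethylamino group or a carboxylic acid on this aromatic carbon would hold the read-out as low remains open. With a single concentration behind each number, compounds 2, 3 and 4 also remain unranked in the strength of their effect at that concentration.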